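The compounds below may be only part of what the source reports. "The series", "measured", "known", "first", "only" and "open" are said of these compounds alone.

Compound 1, `CCCCNC(=O)[C@H]1OC(n2cnc3c(N)ncnc32)[C@H](O)[C@@H]1O`: 17 nM
Compound 2, `CCCCCCNC(=O)[C@H]1OC(n2cnc3c(N)ncnc32)[C@H](O)[C@@H]1O`: 19 nM
Compound 3, `CCCCCCCNC(=O)[C@H]1OC(n2cnc3c(N)ncnc32)[C@H](O)[C@@H]1O`: 20 nM

The three measured compounds share the same core and differ only in the length of the saturated chain attached to the amide-type nitrogen. In an assay on cell membranes for binding affinity to 2-oxoglutarate receptor 1 (Rattus norvegicus), read by radioligand binding (a higher number here means a weaker inhibitor, a lower number a stronger inhibitor), compound 1 gives 17 nM, compound 2 gives 19 nM, and compound 3 gives 20 nM. Compound 3 has the highest of the three numbers, but its nearest neighbour is compound 2 and its furthest is compound 1, and both gaps lie within the scatter, so no real difference among the three can be claimed.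

The steps that lengthen this chain were a 1.1-fold higher number from compound 1 to compound 2 (0.05 log units; within the scatter), a 1.2-fold higher number from compound 1 to compound 3 (0.07 log units; within the scatter) and a 1.1-fold higher number from compound 2 to compound 3 (0.02 log units; within the scatter), all within the scatter.

Compound 4, `CCCCCCCCNC(=O)[C@H]1OC(n2cnc3c(N)ncnc32)[C@H](O)[C@@H]1O`, extends the chain once more: methyl in place of hydrogen on a saturated chain carbon, seven bonds along the chain from an amide-type nitrogen. All three measured steps bear on this change, since each also lengthened the same chain, and none moved the number beyond the scatter. In this assay a step of similar size is therefore expected, neither clearly up nor clearly down. Compound 4 is expected to give 22 nM, with a range from 11 nM to 45 nM. This estimate corresponds to an expected step of a 1.1-fold higher number from compound 3 to compound 4 (0.04 log units; within the scatter).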

Compound 4, inhibition constant: 21 nM
The estimate for compound 4 lay 1.0-fold (0.02 log units) above the measured number; low and high end bracket the measured number.
By their numbers in this assay, from the lowest: compounds 1, 2, 3 and 4 (each within the scatter of the next).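

In this assay, methyl in place of hydrogen on a saturated chain carbon, seven bonds along the chain from an amide-type nitrogen, gave a step that cannot be told from noise (a 1.1-fold higher number from compound 3 to compound 4 (0.02 log units; within the scatter)). The wider comparisons read the same way, with a 1.1-fold higher number from compound 2 to compound 4 (0.04 log units; within the scatter) and a 1.2-fold higher number from compound 1 to compound 4 (0.09 log units; within the scatter), so even the largest difference in chain length shown here, from the chain of compound 1 to that of compound 4, leaves no real difference in the number. No measurement available here explains why these chains read alike.

Going by these compounds, all four compounds carry plain saturated chains, so whether a still longer chain would give the same reading remains open. Also open, on these data alone, is how this assay would read a chain ending in an amine or a carboxylic acid.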